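Trifluoromethoxy in place of ethyl: compound 4 in prospect

The source may report more compounds than this note shows. Statements on the series, on what has been measured and on what is new or still open speak of the compounds shown alone.

In an ADME assay on L6 cells (Rattus norvegicus) for cytotoxicity, read by resazurin assay, with a stated time of 72 h (a higher number here means a weaker inhibitor, a lower number a stronger inhibitor), compound 1 (`CCc1ccc(C(=O)NC(=O)c2ccccc2O)cc1`) gives 70 ug/mL and stands within the scatter of both of its measured relatives. Compound 2 (`Cc1ccc(C(=O)NC(=O)c2ccccc2O)cc1`) gives 46 ug/mL and compound 3 (`O=C(NC(=O)c1ccccc1O)c1ccc(F)cc1`) gives 38 ug/mL in the same measurements. Compound 4 (`O=C(NC(=O)c1ccccc1O)c1ccc(OC(F)(F)F)cc1`) is still unmeasured. The change is trifluoromethoxy in place of ethyl on an aromatic carbon and it puts trifluoromethoxy in place of ethyl on an aromatic carbon, para to a large group.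

Going by the values given here, three measured steps bear on this change. The nearest guide is fluoro in place of ethyl, which gives a 1.8-fold lower number from compound 1 to compound 3 (0.27 log units; within the scatter) and so stays within the scatter. Fluoro in place of methyl gives a 1.2-fold lower number from compound 2 to compound 3 (0.08 log units; within the scatter) and hydrogen in place of methyl on the chain gives a 1.5-fold lower number from compound 1 to compound 2 (0.18 log units; within the scatter) with neither leaving the scatter. Among the compounds with values here, no measured compound carries trifluoromethoxy, so these steps guide the expectation only indirectly. On that basis no step beyond the scatter is expected in this assay and no direction can be called with confidence. The estimated step is a 1.4-fold lower number from compound 1 to compound 4 (0.15 log units; within the scatter) as a central figure only. Compound 4 is expected at 50 ug/mL with an estimated range from 25 ug/mL to 100 ug/mL on this read-out.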

Compound 4, half-maximal inhibitory concentration: 84 ug/mL
Beside the measured number, compound 4's estimate is 1.7-fold (0.23 log units) below it; measured number inside the range.
By their numbers in this assay, from the lowest: compounds 3, 2, 1 and 4 (each within the scatter of the next, the first and the last beyond it).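

In this assay, the aromatic carbon para to a large group now gives its first step beyond the scatter, with trifluoromethoxy in place of fluoro: a 2.2-fold higher number from compound 3 to compound 4 (0.34 log units; beyond the scatter). That modest step is the only one of its kind here, and the other two comparisons do not share it: a 1.2-fold higher number from compound 1 to compound 4 (0.08 log units; within the scatter) and a 1.8-fold higher number from compound 2 to compound 4 (0.26 log units; within the scatter) both stay within the scatter, so replacing ethyl, with its two heavy atoms, by trifluoromethoxy, with its five, does not separate compound 4 from compound 1 on this read-out. Nothing measured here explains why trifluoromethoxy and fluoro stand apart while trifluoromethoxy, ethyl and methyl do not.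

The compounds shown leave open whether an amine, a carboxylic acid or a longer chain on this aromatic carbon would move the number beyond the scatter from compound 1. They also leave open whether the gap between fluoro and trifluoromethoxy would persist with a change elsewhere on the shared core, such as a different group in place of the hydroxyl.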